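The compounds below may be only part of what the source reports. "The series", "measured", "known", "first", "only" and "open" are said of these compounds alone.

Compound 2 (`NC(=O)C(=O)NCCCCCCCC(=O)Nc1ccccc1`) has no number to its name yet. In a functional assay on HCT-116 cells (Homo sapiens) for inhibition, read by colorimetric assay, with a stated time of 3 days (a lower number here means a stronger inhibitor, a higher number a weaker inhibitor), compound 2 gives > 100000 nM and this is a limit of the assay. Compound 1 (`O=C(CCCCCCCNC(=O)c1cc(=O)c(O)co1)Nc1ccccc1`) gives > 100000 nM in this assay and this too is a limit. Compound 3 (`OC(O)(c1c(F)c(F)c(-n2cc(-c3ccccc3)nn2)c(F)c1F)C(F)(F)F`) gives > 100000 nM in this assay and this is likewise a limit. Among the measured compounds shown here, the series so far therefore shows the limit of > 100000 nM in this assay, at which 3 of the 3 values shown sit, and offers no measured potency to work from.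

Compound 4 (`O=C(CCCCCCC(O)C(F)(F)F)Nc1ccccc1`) carries 2,2,2-trifluoro-1-hydroxyethyl in place of the ((carbamoylcarbonyl)amino)methyl of compound 2, on a saturated chain carbon, six bonds along the chain from a carbonyl carbon. The change is counted as 2,2,2-trifluoro-1-hydroxyethyl in place of ((carbamoylcarbonyl)amino)methyl on a saturated chain carbon, six bonds along the chain from a carbonyl carbon and removes the whole amide end of the chain.

For the measured compounds named here, the one measured step that bears on it is a step that the two limits leave unreadable from compound 1 to compound 2 and it gives no size to carry over. The expectation thus rests on the limit of compound 2 at > 100000 nM and no step beyond the scatter is expected in this assay on that ground. The estimate means a number no higher from compound 2 to compound 4 (the limit leaves the size open) as the expected step, with neither direction favoured. The expected value of compound 4 is 100000 nM with 40000 nM as the lower end and 200000 nM as the upper end of the estimate.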

Compound 4, half-maximal inhibitory concentration: > 40000 nM
Compound 4 was reported as a limit; the forecaster's own chance of this, stated with the estimate: 80%; the middle value lies beyond the limit too.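

Compound 2 and compound 4 both stand at limits of the assay, and the step between them cannot be read. The compounds shown leave open how strongly any of them inhibits in this assay: all four values are limits, and none gives a measured potency from which to compare the chain ends.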